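Urea in place of acetamide on an aryl sulfonate

A few compounds are considered here, and "the series" means these few. Any claim that something is new, unique, unknown or untested is made for them only; others in the source may bear on it.

Three compounds share a sulfonate ester between two benzene rings. Compound 1 `CCCC(=O)Nc1cccc(S(=O)(=O)Oc2ccccc2C(C)C)c1` gives 9400 nM in a functional assay on MCF7 cells (Homo sapiens) for antiproliferative activity, read by sulforhodamine B assay, with a stated time of 48 h; on this read-out lower numbers stand for stronger inhibition and higher numbers for weaker inhibition. Compound 2 `CC(=O)Nc1ccc(S(=O)(=O)Oc2ccccc2C(C)C)cc1` gives 16000 nM in this assay, and compound 3 `CC(=O)Nc1ccc(S(=O)(=O)Oc2ccccc2I)cc1` gives 27000 nM in this assay. Among the compounds with values here, compound 3 stands highest of the three numbers: its nearest neighbour is compound 2, and the only single-point step recorded runs a 1.7-fold higher number from compound 2 to compound 3 (0.23 log units; within the scatter); its furthest is compound 1, a difference that lies beyond the scatter. Within the data shown here, compounds 1 and 2 differ in more than one place, so their values are noted but no step is drawn between them.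

Compound 4 `O=C(NCC1CCCC1)Nc1ccc(S(=O)(=O)Oc2ccccc2I)cc1` differs from compound 3 by (cyclopentylmethyl)amino in place of methyl on a carbonyl carbon. Among the measured compounds shown here, no measured step touches this end of the molecule, and the iodo ring is unchanged. The account therefore expects compound 4 to show a step of a 1.8-fold lower number from compound 3 to compound 4 (0.26 log units; within the scatter), essentially none beyond the scatter. Compound 4 is estimated at 15000 nM, with a range from 4000 nM to 60000 nM.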

Compound 4, half-maximal inhibitory concentration: 6600 nM
Compound 4: the middle estimate sits 2.3-fold (0.36 log units) above what was measured; low and high end bracket the measured number.
By their numbers in this assay, from the lowest: compounds 4, 1, 2 and 3 (each within the scatter of the next, the first and the last beyond it).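

In this assay, within the data shown here, (cyclopentylmethyl)amino in place of methyl on a carbonyl carbon gives a 4.1-fold lower number from compound 3 to compound 4 (0.61 log units; beyond the scatter) and is the first single-place step here to lie beyond the scatter, so this end of the molecule, untouched by the earlier step, does bear on the read-out. The change turns the acetamide into a urea and brings in a hydrogen-bond donor and a five-membered non-aromatic ring of carbon only, all at once, so the compounds cannot assign the step to any one of these parts. Nothing measured here says why the number falls.

The compounds shown leave open whether a plain amino group on the same carbonyl carbon would give a similar number. They also leave open how a longer chain such as n-hexylamino, or a carboxylic acid on the cyclopentyl ring, would read.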